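Sulfamide in Place of Succinimide: Expected Cell Toxicity

The compounds below may be only part of what the source reports. "The series", "measured", "known", "first", "only" and "open" are said of these compounds alone.

Of the compounds shown here, three sharing one core have been tested in an ADME assay on HEK293-A cells (Homo sapiens) for cytotoxicity, read by MTT assay, with a stated time of 48 h; on this read-out lower numbers stand for stronger inhibition and higher numbers for weaker inhibition. Compound 1 `O=C1O[C@@H](CN2CCC(O)CC2)CN1c1ccc(-n2cc(-c3ccccn3)cn2)c(F)c1` gives only a limit of the assay, > 400 ug/mL, in this assay. Compound 2 `O=C1CCC(=O)N1C[C@H]1CN(c2ccc(-n3cc(-c4ccccn4)cn3)c(F)c2)C(=O)O1` likewise gives only a limit, > 400 ug/mL. Compound 3 `O=CNC[C@H]1CN(c2ccc(-n3cc(-c4ccccn4)cn3)c(F)c2)C(=O)O1` also gives only a limit, > 400 ug/mL. Among the compounds with values here, because all three sit at the limit of > 400 ug/mL in this assay, at which 3 of the 3 values shown sit, no step between them can be read: a step that the two limits leave unreadable from compound 1 to compound 2, a step that the two limits leave unreadable from compound 1 to compound 3 and a step that the two limits leave unreadable from compound 2 to compound 3 all stay unreadable. Compound 2 thus stands at the same limit as the other two, with nothing to set it apart.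

Compound 4 `CN(C)S(=O)(=O)NC[C@H]1CN(c2ccc(-n3cc(-c4ccccn4)cn3)c(F)c2)C(=O)O1` differs from compound 2 in one place: (dimethylsulfamoyl)amino in place of 2,5-dioxopyrrolidin-1-yl on a saturated chain carbon bound to a saturated ring carbon. The measured steps that bear on this change are those that swap the group on the same saturated chain carbon, and each of them was left unreadable by the limits. They offer no sign of any step beyond the scatter, so the expected step that the limit leaves unreadable from compound 2 to compound 4 is one that cannot be read. Compound 4 is therefore estimated at 500 ug/mL, within 300 ug/mL to 1500 ug/mL, most likely again only a limit.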

Compound 4, half-maximal inhibitory concentration: 249 ug/mL
For compound 4 the middle estimate is 2.0-fold (0.30 log units) above the measured one; the measured number lies below the stated range.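

At the saturated chain carbon, compound 4 gives a measured number, 249 ug/mL, in this assay. The steps among compound 1, compound 2 and compound 3 cannot be read, and only compound 4 stands off the limit: the limit of > 400 ug/mL in this assay, at which 3 of the 4 values shown sit. Placing (dimethylsulfamoyl)amino on this carbon gives an at least 1.6-fold lower number from compound 2 to compound 4 (0.20 log units; that floor lies within the scatter) and an at least 1.6-fold lower number from compound 3 to compound 4 (0.20 log units; that floor lies within the scatter) and also an at least 1.6-fold lower number from compound 1 to compound 4 (0.20 log units; that floor lies within the scatter) as the steps that can now be stated. Within the data shown here, each is only a floor, so this change gives a first reading at this position but does not show a step beyond the scatter.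

From the compounds shown here alone, how large the steps really are stays open, since the other three compounds give only limits. Also open, going by these compounds, is whether methanesulfonylamino, an unsubstituted sulfamoylamino group or a simple amine on the same carbon would give a measured number too.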